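Fluorophenyl position on the shared core

This account rests on a few compounds, and the source may have more. Where it says the series, first, only, none or still open, it means among the compounds named here.

Measured so far:
compound 1 `COc1ccc(C2OC(c3cc(OC)c(OC)c(OC)c3)=NN2C(C)=O)c(OC)c1` — 92%
compound 2 `COc1cc(C2=NN(C(C)=O)C(c3ccc(F)cc3)O2)cc(OC)c1OC` — 0.1%

In a functional assay on PC-3 cells (Homo sapiens) for antiproliferative activity, read by MTT assay, tested at 5 uM (on this read-out lower numbers stand for a weaker effect and higher numbers for a stronger effect at the one concentration tested), compound 2 stands lowest of the two numbers; its nearest neighbour is compound 1, and the step of a number 91.9 percentage points lower from compound 1 to compound 2 (beyond the scatter) lies beyond the scatter. Compound 3 `COc1cc(C2=NN(C(C)=O)C(c3cccc(F)c3)O2)cc(OC)c1OC` is not yet measured. It differs from compound 2 by 3-fluorophenyl in place of 4-fluorophenyl on a saturated ring carbon. Among the compounds with values here, no measured step bears on where the fluorine sits on that ring; the only measured step concerns a different group. The expectation for compound 3 is therefore a step of a number 4.9 percentage points higher from compound 2 to compound 3 (within the scatter), within the scatter. Compound 3 is estimated at 5%, in the range 0% to 25%.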

Compound 3, a percentage reported as inhibition, at one concentration (the size of the read-out at that concentration, not a potency): 43.5%
The estimate for compound 3 lay 38.5 percentage points below the measured number, outside the stated range (above it).
By their numbers in this assay, from the lowest: compound 2; then compound 3; then compound 1.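

In this assay, moving the fluorine alone, with 3-fluorophenyl in place of 4-fluorophenyl on the saturated ring carbon, gives a number 43.4 percentage points higher from compound 2 to compound 3 (beyond the scatter) and shows that the place of the fluorine on this ring counts on its own. A fluorophenyl group at this position therefore does not go with a near-zero read-out in every case. The better of the two fluorophenyl groups still falls short of 2,4-dimethoxyphenyl, with a number 48.5 percentage points lower from compound 1 to compound 3 (beyond the scatter) on that change.

As far as these compounds go, whether a chlorine, a hydroxyl or an amine in the fluorine's place would show the same dependence on ring position stays open. Nothing available on these compounds explains the difference between the two fluorine positions.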